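This account rests on a few compounds, and the source may have more. Where it says the series, first, only, none or still open, it means among the compounds named here.

Compound 1 `COc1cc(/C=N/Nc2nc(-c3ccc(C(F)(F)F)cc3)cs2)c(Br)c(Br)c1OC` and compound 2 `COc1cc(/C=N/Nc2nc(-c3ccccc3)cs2)c(Br)c(Br)c1OC` share one core and differ only in a single group on a six-membered aromatic ring of carbon only. In a functional assay on HepG2 cells (Homo sapiens) for inhibition, read by MTT assay, with a stated time of 48 h (a higher number here means a weaker inhibitor, a lower number a stronger inhibitor), compound 1 gives no number but only a limit, > 100000 nM. In this assay compound 2 gives 33600 nM. The step of an at least 2.9-fold lower number from compound 1 to compound 2 (0.47 log units; beyond the scatter) is at least modest, so exchanging trifluoromethyl for hydrogen made the compound a stronger inhibitor. Among the measured compounds shown here, compound 2 therefore holds the only actual number in this set; the other value is a limit.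

Compound 3 `COc1ccccc1-c1csc(N/N=C/c2cc(OC)c(OC)c(Br)c2Br)n1` has not yet been measured. It differs from compound 2 by methoxy in place of hydrogen on an aromatic carbon. For the measured compounds named here, no measured step puts methoxy in place of hydrogen; the only step available, an at least 2.9-fold lower number from compound 1 to compound 2 (0.47 log units; beyond the scatter), changes a different group on the same ring and gives no direction for a methoxy group entering. For compound 3 a step in this assay of no more than the usual scatter is expected, in either direction. The estimate for compound 3 is 30000 nM, with a range from 8000 nM to 100000 nM. The expected step is a 1.1-fold lower number from compound 2 to compound 3 (0.05 log units; within the scatter).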

Compound 3, half-maximal inhibitory concentration: > 100000 nM
Compound 3 gave a limit, no number; the forecaster's own chance of this, stated with the estimate: 20%; at least 3.3-fold (0.52 log units) between middle value and limit.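

Methoxy in place of hydrogen on this aromatic carbon, ortho to a large group, gives an at least 2.9-fold higher number from compound 2 to compound 3 (0.47 log units; beyond the scatter) in this assay, so this change made the compound a weaker inhibitor. Among the compounds shown here, this is the first measured step in which a group enters this ring in place of hydrogen at this spot, and it shows that phenyl to 2-methoxyphenyl is not a neutral swap; among the three compounds, the two that carry a group on this ring, trifluoromethyl in compound 1 and methoxy in compound 3, both lie on the weaker side of compound 2, and none goes against this. The steps between the two limited compounds cannot be read, so trifluoromethyl and methoxy cannot be ranked against each other, and the comparison rests on one actual number and this limit: the limit of > 100000 nM in this assay, at which 2 of the 3 values shown sit.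

On these data alone, how far compound 3 really lies from compound 2 stays unknown, as does whether methoxy on another carbon of this ring would give the same result. Nor do these compounds show what a hydroxyl group, an amine or a carboxylic acid would do at this same carbon.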